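This account rests on a few compounds, and the source may have more. Where it says the series, first, only, none or still open, it means among the compounds named here.

Compound 1 `COCC(C(=O)N1CCN(c2cccc(C(F)(F)F)c2)CC1)N1C(=O)CCC1=O` gives 50%. Compound 2 `CC(C(=O)N1CCN(c2ccc(Cl)cc2)CC1)N1C(=O)CCC1=O` gives 0%. Compound 3 `CCC(C(=O)N1CCN(c2ccccc2F)CC1)N1C(=O)CCC1=O` gives 0%.

All three were tested in a functional assay on the whole organism (strain Swiss) with Mus musculus as the target, in the maximal electroshock model, with a stated time of 1 h, at a dose of 100 mg/kg by the intraperitoneal route; a higher number here means a stronger effect of the compound at the dose given, a lower number a weaker effect. On these numbers compound 2 stands level with compound 3 at the digits reported, and the two together hold the lowest values of the three. The gap between compound 2 and compound 1 is the widest one here: compound 1 sits higher by a margin well beyond the usual scatter, while compound 2 and compound 3 cannot be told apart.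

Compound 4 `CC(C(=O)N1CCN(c2cccc(F)c2)CC1)N1C(=O)CCC1=O` has not been measured. It differs from compound 2 in one place: 3-fluorophenyl in place of 4-chlorophenyl on an amine nitrogen in a ring. The shared core and the methyl group on the chain are unchanged.

Among the compounds with values here, no pair of measured compounds differs in exactly this way, so the size of the step is not known. Within the data shown here, compound 1, the only compound with a group in the 3-position of its phenyl ring, also carries a different chain, so its higher value cannot be assigned to the ring alone. Given that compound 2 gives 0%, the expected step is a small rise, a number 10 percentage points higher from compound 2 to compound 4 (within the scatter), within the scatter. Compound 4 is therefore estimated at 10%, with a range from 0% to 40%.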

Compound 4, a percentage reported as activity, at one dose (the size of the read-out at that dose, not a potency): 0%
Beside the measured number, compound 4's estimate is 10 percentage points above it; low and high end bracket the measured number.
By their numbers in this assay, from the lowest: compounds 2, 3 and 4 (each within the scatter of the next); then compound 1.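

In this assay, within the data shown here, the exchange of 4-chlorophenyl for 3-fluorophenyl on the amine nitrogen in a ring gives no change at the digits printed from compound 2 to compound 4 (within the scatter) and is the first step at this position that can be read. With the methyl group on the chain held fixed, fluorine in the 3-position of the phenyl ring gives a read-out that cannot be told from that of chlorine in the 4-position. With compound 2 at 0% and compound 4 at 0% neither shows any effect at the dose given, so the step cannot show whether the two rings would differ if the read-out were above zero, and nothing measured here explains the result.

Among these compounds, the exchange alters the halogen and its place on the ring in one move, so the two changes cannot be separated, and compound 1 differs from compound 4 in more than one place, so no step to it can be read. On these data alone, it remains open whether a phenyl ring carrying a nitrile or a methoxy group, or a longer chain in place of the methyl group, would lift the number at all.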